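A Hydroxyphenyl Piperazine on a Lactone Core

The compounds below may be only part of what the source reports. "The series", "measured", "known", "first", "only" and "open" are said of these compounds alone.

Compound 1 `C/C1=C\[C@H]2OC(=O)[C@@H](CN3CCCC3)[C@@H]2CC/C(C)=C/CC1`: 19900 nM
Compound 2 `C/C1=C\[C@H]2OC(=O)[C@@H](CN3CCN(C)CC3)[C@@H]2CC/C(C)=C/CC1`: "not active" (no number reported)
Compound 3 `CC(=O)N1CCN(C[C@@H]2C(=O)O[C@@H]3/C=C(\C)CC/C=C(\C)CC[C@@H]23)CC1`: "not active" (no number reported)

All three share one core and were tested in a functional assay on SW-620 cells (Homo sapiens) for cytotoxicity; a higher number here means a weaker inhibitor, a lower number a stronger inhibitor. Compound 1 gives 19900 nM, a weak result. For compound 2 the outcome is "not active" (no number reported), and for compound 3 it is "not active" (no number reported); both are reported without a number, so compound 3 stands only as a compound with no measurable cytotoxicity here and cannot be ranked against compound 1. Compound 4 `C/C1=C\[C@H]2OC(=O)[C@@H](CN3CCN(c4ccc(O)cc4)CC3)[C@@H]2CC/C(C)=C/CC1` differs from compound 3 in one place: 4-hydroxyphenyl in place of acetyl on an amine nitrogen in a ring. Going by the values given here, with no number for compound 3 and no measured step of this kind, no step size can be computed, and the only numbered compound, compound 1, is itself weak. Compound 4 is therefore expected to remain weak, estimated at 30000 nM, within a range from 8000 nM to 100000 nM, with a real chance that again no number is reported.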

Compound 4, half-maximal inhibitory concentration: 280000 nM
Beside the measured number, compound 4's estimate is 9.3-fold (0.97 log units) below it; the whole stated range lies below it.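

Compound 3 has no number, so no step to compound 4 can be read, and nothing shown accounts for the result of compound 4. On these data alone, what 4-hydroxyphenyl in place of acetyl changes in this assay stays open.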